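The source may report more compounds than this note shows. Statements on the series, on what has been measured and on what is new or still open speak of the compounds shown alone.

Measured compounds:
Compound 1, `CS(=O)(=O)c1ccc(Nc2ncc(F)c(Nc3nc4ccccc4s3)n2)cc1`: 6880 nM
Compound 2, `CS(=O)(=O)c1ccc(Nc2ncc(F)c(Nc3nc4ccc(F)cc4s3)n2)cc1`: > 50000 nM
Compound 3, `NS(=O)(=O)c1ccc(Nc2nccc(Nc3nc4ccccc4s3)n2)cc1`: 15300 nM

In a functional assay on MCF7 cells (Homo sapiens) for antiproliferative activity, read by MTT assay, with a stated time of 48 h (on this read-out lower numbers stand for stronger inhibition and higher numbers for weaker inhibition), compound 1 gives 6880 nM. Compound 2 reaches only the limit of the assay, > 50000 nM, which is a limit and not a number. Compound 2 differs from compound 1 by a single change: fluoro in place of hydrogen on an aromatic carbon. That change gave an at least 7.2-fold higher number from compound 1 to compound 2 (0.86 log units; beyond the scatter), a size that rests on (the limit of > 50000 nM in this assay, at which 1 of the 3 values shown sits), so the true size of the step is not known beyond that. Compound 3 gives 15300 nM in this assay, and how its core differs from the core of compound 1 is not broken down here; its value sits beyond the scatter from that of compound 1.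

Compound 4, `NS(=O)(=O)c1ccc(Nc2nccc(Nc3nc4ccc(F)cc4s3)n2)cc1`, has not yet been measured in this assay. It differs from compound 3 by the same change that separates compound 2 from compound 1, at the same place: fluoro in place of hydrogen on an aromatic carbon. Because the earlier instance gave an at least 7.2-fold higher number from compound 1 to compound 2 (0.86 log units; beyond the scatter), the step from compound 3 to compound 4 is expected to be a 4.6-fold higher number from compound 3 to compound 4 (0.66 log units; beyond the scatter), which would carry compound 4 past (the limit of > 50000 nM in this assay, at which 1 of the 3 values shown sits). Compound 4 is therefore estimated at 70000 nM in this assay. The expected range for compound 4 runs from 20000 nM to 200000 nM, and it is expected that the assay may report only a limit for compound 4 rather than a number.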

Compound 4, half-maximal inhibitory concentration: 10900 nM
The estimate for compound 4 lay 6.4-fold (0.81 log units) above the measured number, outside the stated range (below it).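

In this assay, the same replacement of hydrogen by fluoro, on an aromatic carbon at the same place, gave a 1.4-fold lower number from compound 3 to compound 4 (0.15 log units; within the scatter), so compound 3 and compound 4 cannot be told apart on this read-out. The change therefore did not carry over from the core of compound 1 to the core of compound 3, and the two steps differ: the same change on two cores in this assay, an at least 7.2-fold higher number (0.86 log units; beyond the scatter) from compound 1 to compound 2 and a 1.4-fold lower number (0.15 log units; within the scatter) from compound 3 to compound 4, at least 10-fold (1.00 log units) apart, beyond the scatter of two such steps What lies behind this difference is not shown, and with only two cores no rule can be drawn about which cores respond to the change; the earlier step also has no known full size, as compound 2 stands only at a limit: the limit of > 50000 nM in this assay, at which 1 of the 4 values shown sits.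

The compounds shown leave open how a chloro or a methoxy group in place of that same hydrogen would read on either core. They also leave open whether the fluoro change on a third core would resemble the step seen on the core of compound 1 or the one seen on the core of compound 3.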